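Fluoro for chloro on a bithiophene amidine

The source may report more compounds than this note shows. Statements on the series, on what has been measured and on what is new or still open speak of the compounds shown alone.

Compound 1 `N=C(N)c1ccc(-c2ccc(-c3ccc(Cl)cc3)s2)s1` gives 13000 nM in a functional assay on A498 cells (Homo sapiens) for inhibition, read by sulforhodamine B assay, with a stated time of 48 h; on this read-out lower numbers stand for stronger inhibition of growth and higher numbers for weaker inhibition of growth.
Compound 2 `N=C(N)c1ccc(-c2ccc(-c3ccc(F)cc3)o2)o1` gives 1900 nM in this assay.

Of the two measured compounds, compound 1 stands at the higher number; compound 2 stands at a lower number, and the gap between the two lies beyond the usual scatter. Going by the values given here, the two compounds differ in more than one place, so their values show only that compound 2 inhibits growth more strongly in this assay.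

Compound 3 `N=C(N)c1ccc(-c2ccc(-c3ccc(F)cc3)s2)s1` is not yet measured. It differs from compound 1 in one place: fluoro in place of chloro on an aromatic carbon. Among the compounds with values here, there is no measured pair with this same exchange on the shared core, so the size of the effect is not known from the data. A step of modest size is expected, with a 1.4-fold lower number from compound 1 to compound 3 (0.16 log units; within the scatter) estimated to fall within or only slightly beyond the scatter, most likely toward a lower number. Compound 3 is therefore expected to give about 9000 nM in this assay, within a range from 3000 nM to 27000 nM.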

Compound 3, concentration for 50% growth inhibition: 1950 nM
Compound 3: middle estimate off by 4.6-fold (0.66 log units), on the high side; measured number below the stated range.
By their numbers in this assay, from the lowest: compounds 2 and 3 (each within the scatter of the next); then compound 1.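

In this assay, fluoro in place of chloro on an aromatic carbon, para to a large group, gives a 6.7-fold lower number from compound 1 to compound 3 (0.82 log units; beyond the scatter). Going by these compounds alone, this pair shows that growth inhibition in this assay responds to the exchange of one halogen for another at this position, which the earlier compounds could not show since they differed in more than one place. No measured evidence here accounts for the size or direction of this step.

The compounds shown leave open whether the same exchange gives a step of similar size on the core of compound 2, and how a methoxy or trifluoromethyl group would compare with fluoro at this position. They also leave open what an amine or a carboxylic acid in place of the amidine would do.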